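Shifting the dioxoimidazolidinyl ring outward on the chain

The source may hold more compounds than are shown below. What is called first, only, known or untested is meant among the compounds shown, and "the series" means these compounds.

Of the compounds shown here, three sharing one core have been measured. Compound 3 `CC(C)C(c1ccc(-c2ccc3cccc(F)c3c2)[nH]c1=O)C1SC(=O)NC1=O` gives 25 nM in an assay on membranes from Chem-1 cells for displacement of a labelled ligand from prostaglandin E2 receptor EP3 subtype (Homo sapiens), read by scintillation counting, with a stated time of 2 h (a higher number here means a weaker inhibitor, a lower number a stronger inhibitor), the lowest of the three numbers. Compound 1 `CC(C)C(c1ccc(-c2ccc3cccc(F)c3c2)[nH]c1=O)C1NC(=O)NC1=O` gives 50 nM in this assay, within the scatter of compound 3, while compound 2 `CCC(/C=C1\OC(=O)NC1=O)(CC)c1ccc(-c2ccc3cccc(C(C)C)c3c2)[nH]c1=O` gives 120 nM, beyond the scatter. Compound 4 `CC(C)C(CC1NC(=O)NC1=O)c1ccc(-c2ccc3cccc(F)c3c2)[nH]c1=O` is not yet measured; it carries (2,5-dioxoimidazolidin-4-yl)methyl in place of 2,4-dioxo-1,3-thiazolidin-5-yl on a saturated chain carbon bound to an aromatic carbon and a saturated chain carbon. For the measured compounds named here, the only step bearing on this is a 2.0-fold lower number from compound 1 to compound 3 (0.30 log units; within the scatter), which exchanged the same two ring types without the added chain carbon. Reversing that exchange is expected to change little, and nothing measured tells what the extra chain carbon does. The move is therefore expected to amount to a 2.2-fold higher number from compound 3 to compound 4 (0.34 log units; beyond the scatter). Compound 4 is expected to give 55 nM in this assay, between 20 nM and 160 nM.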

Compound 4, inhibition constant: 10 nM
Compound 4: middle estimate off by 5.5-fold (0.74 log units), on the high side, outside the stated range (below it).
By their numbers in this assay, from the lowest: compound 4; then compounds 3 and 1 (each within the scatter of the next); then compound 2.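

Placing the added chain carbon ahead of the same ring, as (2,5-dioxoimidazolidin-4-yl)methyl, gives a 5.0-fold lower number from compound 1 to compound 4 (0.70 log units; beyond the scatter) in this assay and shows that this position accepts a longer reach. The exchange of 2,4-dioxo-1,3-thiazolidin-5-yl for that group gives a 2.5-fold lower number from compound 3 to compound 4 (0.40 log units; beyond the scatter) but changes both ring and chain at once. No measurement shown accounts for either gain.

On these data alone, it remains open whether 2,4-dioxo-1,3-thiazolidin-5-yl on the same added chain carbon would match compound 4. As far as these compounds go, it is also open whether a longer chain carrying the 2,5-dioxoimidazolidin-4-yl ring would lower the number further.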